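This account rests on a few compounds, and the source may have more. Where it says the series, first, only, none or still open, it means among the compounds named here.

Among the measured compounds shown here, in a functional assay on HeLa cells (Homo sapiens) for cytotoxicity, read by ELISA, with a stated time of 4 days (on this read-out higher numbers stand for weaker inhibition and lower numbers for stronger inhibition), compound 1 `Cc1ccc(-c2cc(-c3ccoc3)cc(-c3ccc(Cl)s3)n2)o1` gives 26500 nM and compound 2 `Cc1ccccc1-c1cc(-c2ccoc2)cc(-c2ccc(Cl)s2)n1` gives 19000 nM, so compound 2 stands level with the only other measured compound. Compound 3 `Cc1cccc(-c2cc(-c3ccoc3)cc(-c3ccc(Cl)s3)n2)c1` differs from compound 2 by 3-methylphenyl in place of 2-methylphenyl on an aromatic carbon, next to the ring nitrogen. For the measured compounds named here, the one measured step that bears on this is the exchange of groups on that same carbon, a 1.4-fold lower number from compound 1 to compound 2 (0.14 log units; within the scatter). As that step stayed within the scatter, no step beyond the scatter is expected in this assay. The expected result is a 1.1-fold lower number from compound 2 to compound 3 (0.02 log units; within the scatter). Compound 3 is estimated at 18000 nM, with an expected range of 8000 nM to 40000 nM.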

Compound 3, half-maximal inhibitory concentration: 23600 nM
Beside the measured number, compound 3's estimate is 1.3-fold (0.12 log units) below it, and the stated range covers the measured number.
By their numbers in this assay, from the lowest: compounds 2, 3 and 1 (each within the scatter of the next).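

In this assay, among the compounds shown here, the change to 3-methylphenyl from 2-methylphenyl gives a 1.2-fold higher number from compound 2 to compound 3 (0.09 log units; within the scatter) and so shifts only the place of the methyl on the phenyl ring, which the earlier compounds did not test. The exchange of 5-methylfuran-2-yl for 3-methylphenyl gives a 1.1-fold lower number from compound 1 to compound 3 (0.05 log units; within the scatter) and adds a third group on this carbon that reads alike with the other two. Nothing measured here offers an account of this sameness.

Going by these compounds, whether an amine or a carboxylic acid on this carbon would give a step beyond the scatter stays open. So does the effect of replacing the furan-3-yl or 5-chlorothiophen-2-yl group.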